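Aryl in Place of Oxolanylmethyl on a Thiophene Urea

The source may report more compounds than this note shows. Statements on the series, on what has been measured and on what is new or still open speak of the compounds shown alone.

Measured compounds:
compound 1 `CCN1CCc2c(sc(NC(=O)NCC3CCCO3)c2C(N)=O)C1`: > 25000 nM
compound 2 `CCN1CCc2c(sc(NC(=O)Nc3ccc(Cl)cc3)c2C(=O)NCCO)C1`: 9400 nM
compound 3 `C[N+]1(CC2CC2)CCc2c(sc(NC(=O)Nc3ccc(Cl)cc3)c2C(N)=O)C1`: 360 nM

In a functional assay (strain AB) with Danio rerio as the target, read by microscopy, with a stated time of 1 h (a lower number here means that less compound is needed, a higher number that more compound is needed for the effect), compound 1 gives > 25000 nM, which is a limit of the assay and not a number. Going by the values given here, compound 1 therefore stands at the limit of > 25000 nM in this assay, at which 1 of the 3 values shown sits; of the three measured compounds it is the only one without a numerical value. Compound 2 gives 9400 nM in this assay. Compound 3 gives 360 nM in this assay. Both compound 2 and compound 3 carry an aryl group on the urea nitrogen, and both give a number within the range of this assay, whereas compound 1, with (oxolan-2-yl)methyl there, does not.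

Compound 4 `CCN1CCc2c(sc(NC(=O)Nc3cccc(C)c3)c2C(N)=O)C1` has not yet been measured. It differs from compound 1 in one place: 3-methylphenyl in place of (oxolan-2-yl)methyl on an amide-type nitrogen. Among the compounds with values here, since compound 1 gives only a limit, no measured step leads to compound 4, and the expected size of the step rests on compounds 2 and 3 alone. Compound 4 is expected to need less compound than compound 1, with the step from compound 1 to compound 4 estimated as an at least 4.1-fold lower number from compound 1 to compound 4 (0.61 log units; beyond the scatter). The value of compound 4 in this assay is estimated at 6000 nM, with a range from 1500 nM to 25000 nM.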

Compound 4, half-maximal effective concentration: 13000 nM
Beside the measured number, compound 4's estimate is 2.2-fold (0.34 log units) below it; the range from low to high includes it.
By their numbers in this assay, from the lowest: compound 3; then compounds 2 and 4 (each within the scatter of the next). At a limit, above all of these: compound 1.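

In this assay, going by these compounds alone, compound 4 gives the first comparison at this position in which only the group on the amide-type nitrogen changes, with 3-methylphenyl in place of (oxolan-2-yl)methyl and the rest of the shared core kept. This pair gives an at least 1.9-fold lower number from compound 1 to compound 4 (0.28 log units; that floor lies within the scatter), so the change can be given only as a floor and not as a measured size. The value of compound 1 is a limit of the assay, and it is this limit that leaves one end of the step unfixed: the limit of > 25000 nM in this assay, at which 1 of the 4 values shown sits.

The compounds shown leave open how far the true value of compound 1 lies from that limit, and with it how large this step really is. They also leave open how an unsubstituted phenyl, a pyridin-3-yl or a longer chain such as 3-methoxypropyl on this same nitrogen would compare with compound 4 when the rest of the molecule is kept, and so whether the methyl group or the aromatic ring itself accounts for any part of the step.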